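Pentyloxy to isopropoxy: a branched chain in the series

The source may hold more compounds than are shown below. What is called first, only, known or untested is meant among the compounds shown, and "the series" means these compounds.

In a functional assay on PC-3 cells (Homo sapiens) for antiproliferative activity, read by WST assay, with a stated time of 3 days (on this read-out higher numbers stand for weaker inhibition and lower numbers for stronger inhibition), compound 1 (`CCCOc1c(-c2cc(OC)c(OC)c(OC)c2)oc2ccccc2c1=O`) gives 11800 nM and compound 2 (`CCCCCOc1c(-c2cc(OC)c(OC)c(OC)c2)oc2ccccc2c1=O`) gives 22200 nM on the same read-out, so compound 2 stands within the scatter of compound 1 and the two cannot be ranked. Compound 3 (`COc1cc(-c2oc3ccccc3c(=O)c2OC(C)C)cc(OC)c1OC`) is still unmeasured. The change from compound 2 is isopropyl in place of pentyl on an oxygen on an aromatic ring in all, that is, isopropyl in place of pentyl on an oxygen on an aromatic ring. Among the measured compounds shown here, one measured step bears on it: a 1.9-fold higher number from compound 1 to compound 2 (0.27 log units; within the scatter) for the chain change between the two measured compounds. No branched chain has been measured, so this is only a loose guide. In this assay a small move toward compound 1 at 11800 nM is expected, with nothing beyond the scatter. The expected step is a 1.7-fold lower number from compound 2 to compound 3 (0.23 log units; within the scatter) on this estimate. The estimate for compound 3 is 13000 nM and its value is expected to lie between 6000 nM and 27000 nM.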

Compound 3, half-maximal inhibitory concentration: 21200 nM
Compound 3: middle estimate off by 1.6-fold (0.21 log units), on the low side; the range from low to high includes it.
By their numbers in this assay, from the lowest: compounds 1, 3 and 2 (each within the scatter of the next).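

In this assay, the branched isopropyl chain on the oxygen reads no differently from either straight chain: a 1.0-fold lower number from compound 2 to compound 3 (0.02 log units; within the scatter), and a 1.8-fold higher number from compound 1 to compound 3 (0.25 log units; within the scatter). At this position, on an oxygen on an aromatic ring, branching therefore adds a new chain shape without separating compound 3 from compound 1 or compound 2, and the three chains cannot be ranked. Nothing at hand offers an explanation for this flat reading.

Still open, on these data alone, is whether a chain ending in an amine or a carboxylic acid, a longer chain such as decyl, or a bare hydroxyl at this oxygen would give a step beyond the scatter. Also open, as far as these compounds go, is whether changes elsewhere on the shared core would do so.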